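Trichlorophenyl Peroxide Inhibitors of L02 Cell Growth

The source may report more compounds than this note shows. Statements on the series, on what has been measured and on what is new or still open speak of the compounds shown alone.

The measured compounds and their values:
compound 1 `C=C(c1ccc(Cl)c(Cl)c1)C1COC2(CCCCC2)OO1`: 83500 nM
compound 2 `C=C(c1ccc(Cl)c(Cl)c1Cl)C1COC2(CCCC2)OO1`: 1190 nM
compound 3 `C=C(c1ccc(Cl)c(Cl)c1)C1COC2(CCCC2)OO1`: 8450 nM

In a functional assay on L02 cells (Homo sapiens) for inhibition, read by MTT assay, with a stated time of 72 h (a higher number here means a weaker inhibitor, a lower number a stronger inhibitor), compound 1 gives 83500 nM, the highest of the three numbers. Compound 3 gives 8450 nM, and compound 2 gives 1190 nM. Compound 3 and compound 2 share a core and differ by one change, (chloro in place of hydrogen on an aromatic carbon); this gave a 7.1-fold lower number from compound 3 to compound 2 (0.85 log units; beyond the scatter). Compound 1 and compound 3 carry different cores; the difference between the two cores is not broken down here.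

Compound 4 `C=C(c1ccc(Cl)c(Cl)c1Cl)C1COC2(CCCCC2)OO1` has not yet been measured. It is made from compound 1 by chloro in place of hydrogen on an aromatic carbon, the same change as from compound 3 to compound 2, with the same surroundings at the place of change. Among the compounds shown this change occurs two times in all. Because the earlier step gave a 7.1-fold lower number from compound 3 to compound 2 (0.85 log units; beyond the scatter) on the other core, a step of the same kind is expected on the core of compound 1, so compound 4 is estimated to show a 7.0-fold lower number from compound 1 to compound 4 (0.84 log units; beyond the scatter) in this assay. Compound 4 is therefore expected to give about 12000 nM, likely between 4000 nM and 40000 nM.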

Compound 4, half-maximal inhibitory concentration: 1220 nM
Compound 4: the middle estimate sits 9.8-fold (0.99 log units) above what was measured, and the stated range ends above it.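

In this assay, chloro in place of hydrogen on the aromatic carbon gave a 68-fold lower number from compound 1 to compound 4 (1.84 log units; beyond the scatter), so the number fell on both cores, but by clearly different amounts: the same change on two cores in this assay, a 7.1-fold lower number (0.85 log units; beyond the scatter) from compound 3 to compound 2 and a 68-fold lower number (1.84 log units; beyond the scatter) from compound 1 to compound 4, 9.6-fold (0.98 log units) apart, beyond the scatter of two such steps. The direction of the step thus held on the two cores in this series, while its size did not, and a size read on one core proved a poor guide to the size on the other. With the chloro group in place, compound 2 gives 1190 nM and compound 4 gives 1220 nM, but two pairs do not show why the step differs in size, nor how it would run on any further core.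

The compounds shown leave open whether a bromo, methyl or methoxy group at the same aromatic carbon would give a step like either of these. They also leave open how the chloro step would run on a core carrying an amine or a longer chain.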